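This account rests on a few compounds, and the source may have more. Where it says the series, first, only, none or still open, it means among the compounds named here.

Measured so far in an assay on CHO cells for displacement of a labelled ligand from 5-hydroxytryptamine receptor 1D (Homo sapiens); a lower number here means a stronger inhibitor, a higher number a weaker inhibitor:
compound 1 `CN(Cc1cccs1)C1CCN(CCCc2c[nH]c3ccc(-n4cnnc4)cc23)CC1` — 4.3 nM
compound 2 `CN(Cc1ccco1)C1CCN(CCCc2c[nH]c3ccc(-n4cnnc4)cc23)CC1` — 9.3 nM

Compound 2 gives the higher of the two numbers in this assay; the two are separated by a 2.2-fold higher number from compound 1 to compound 2 (0.34 log units; beyond the scatter), a modest move beyond the scatter. Compound 3 `CC(=O)Nc1ccc(CN(C)C2CCN(CCCc3c[nH]c4ccc(-n5cnnc5)cc34)CC2)cc1` carries 4-acetamidophenyl in place of furan-2-yl on a saturated chain carbon bound to an amine nitrogen. Among the measured compounds shown here, the only measured step, from compound 1 to compound 2, exchanges one five-membered aromatic ring for another at the same chain carbon and moves the number by a 2.2-fold higher number from compound 1 to compound 2 (0.34 log units; beyond the scatter); the change to compound 3 is of a different kind, swapping the five-membered ring for a six-membered aromatic ring of carbon only that bears an acetamido group, so that step is only a rough guide to how much this position tolerates. With nothing closer to lean on, the number for compound 3 is expected to lie near that of compound 2, with a wide range: a 1.3-fold higher number from compound 2 to compound 3 (0.11 log units; within the scatter). Compound 3 is therefore estimated at 12 nM (range 3 nM to 50 nM).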

Compound 3, half-maximal inhibitory concentration: 19 nM
Beside the measured number, compound 3's estimate is 1.6-fold (0.20 log units) below it, within the range that was stated.
By their numbers in this assay, from the lowest: compound 1; then compound 2; then compound 3.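

In this assay, the place on a saturated chain carbon bound to an amine nitrogen also accepts a six-membered aromatic ring of carbon only bearing an acetamido group, with a 2.0-fold higher number from compound 2 to compound 3 (0.31 log units; beyond the scatter) and a 4.4-fold higher number from compound 1 to compound 3 (0.65 log units; beyond the scatter) as the price. Going from 5 to 10 heavy atoms and adding a hydrogen-bond donor therefore leaves the number on a modest step from either five-membered ring, so this place is not limited to small five-membered aromatic rings. Nothing available accounts for the size of either step.

Open, going by these compounds, is how much of the change belongs to the six-membered ring and how much to the acetamido group. A plain phenyl group, or a phenyl group bearing an amine or a carboxylic acid in place of the acetamido group, would separate the two.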